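The source may report more compounds than this note shows. Statements on the series, on what has been measured and on what is new or still open speak of the compounds shown alone.

The measured compounds and their values:

Compound 1, `CC1C(=O)c2nc(CCCN3N=C(Cl)CCC3=O)[nH]c2N(C)C1=O`: in an assay on isolated protein for binding affinity to adenosine receptor A1 (Homo sapiens) (on this read-out higher numbers stand for weaker inhibition and lower numbers for stronger inhibition), compound 1 gives 8800 nM.
Compound 2, `CC1C(=O)c2nc(CCCN3N=C(c4ccccc4)CCC3=O)[nH]c2N(C)C1=O`: in this assay compound 2 gives 10800 nM.
Compound 3, `CCCC1C(=O)c2nc(CN3N=C(Cl)CCC3=O)[nH]c2N(C)C1=O`: in this assay compound 3 gives 9200 nM.

All three values lie within the usual scatter of one another, so none of the three can be called stronger or weaker than the others on this read-out. Compound 2 differs from compound 1 in one place: phenyl in place of chloro on a carbon with a double bond to nitrogen. The step that this change made is a 1.2-fold higher number from compound 1 to compound 2 (0.09 log units; within the scatter), a difference too small to count as a real change.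

Compound 3 shares its atoms with compound 1, but they are joined differently; the difference between the two cores is not broken down here. The unmeasured compound 4, `CCCC1C(=O)c2nc(CN3N=C(c4ccccc4)CCC3=O)[nH]c2N(C)C1=O`, differs from compound 3 in exactly the way compound 2 differs from compound 1: phenyl in place of chloro on a carbon with a double bond to nitrogen. The surroundings of the place are the same word for word in both cases, so this is the same change, occurring twice among the compounds shown.

Given that the one measured instance of this change was a 1.2-fold higher number from compound 1 to compound 2 (0.09 log units; within the scatter), the expectation for compound 4 is a step of about a 1.2-fold higher number from compound 3 to compound 4 (0.08 log units; within the scatter), a number close to that of compound 3. Compound 4 is therefore estimated at 11000 nM in this assay, most likely falling between 5000 nM and 25000 nM.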

Compound 4, inhibition constant: 2270 nM
For compound 4 the middle estimate is 4.8-fold (0.69 log units) above the measured one; measured number below the stated range.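

In this assay, putting phenyl in place of chloro on the core of compound 3 gave a 4.1-fold lower number from compound 3 to compound 4 (0.61 log units; beyond the scatter), so here the swap brought a real, though modest, gain in binding, whereas on the core of compound 1 it brought no change that can be told from the scatter. The outcome of this one swap therefore depends on the core that carries it, and a step read on one core could not be transferred to the other in this series: the same change on two cores in this assay, a 1.2-fold higher number (0.09 log units; within the scatter) from compound 1 to compound 2 and a 4.1-fold lower number (0.61 log units; beyond the scatter) from compound 3 to compound 4, 5.0-fold (0.70 log units) apart, beyond the scatter of two such steps. For the compounds shown here, this shows that the two cores, which hold the same atoms joined differently, responded differently to the same swap, but with only two pairs it does not show why, nor which feature of the cores is responsible, nor how any further core would respond.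

The compounds shown leave open whether a smaller carbon group such as methyl, or an amine or a methoxy group, on the carbon with a double bond to nitrogen would follow phenyl or chloro on each core. They also leave open whether a substituted phenyl, such as one carrying a fluorine, would move the number on the core of compound 3 any further.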